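Exchanging 3-nitrophenyl for 2,3-dichlorophenyl on the shared core

This account rests on a few compounds, and the source may have more. Where it says the series, first, only, none or still open, it means among the compounds named here.

In a functional assay on HepG2 cells (Homo sapiens) for antiproliferative activity, read by MTT assay, with a stated time of 72 h (on this read-out higher numbers stand for weaker inhibition and lower numbers for stronger inhibition), compound 1 `O=C(N/N=C/c1ccccc1)Nc1ccc(Oc2ccnc3[nH]ccc23)c(F)c1` gives 640 nM, compound 2 `O=C(N/N=C/c1ccc(Br)cc1)Nc1ccc(Oc2ccnc3[nH]ccc23)c(F)c1` gives 1000 nM and compound 3 `O=C(N/N=C/c1cccc([N+](=O)[O-])c1)Nc1ccc(Oc2ccnc3[nH]ccc23)c(F)c1` gives 5180 nM. Compound 3 has the highest number of the three, and its steps to both others lie beyond the scatter.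

Compound 4 `O=C(N/N=C/c1cccc(Cl)c1Cl)Nc1ccc(Oc2ccnc3[nH]ccc23)c(F)c1` carries 2,3-dichlorophenyl in place of 3-nitrophenyl on a carbon with a double bond to nitrogen.

Going by the values given here, three measured steps bear on this change. Bromo in place of hydrogen gives a 1.6-fold higher number from compound 1 to compound 2 (0.19 log units; within the scatter), which stays within the scatter. Nitro in place of hydrogen gives an 8.1-fold higher number from compound 1 to compound 3 (0.91 log units; beyond the scatter), a modest step. The exchange of 4-bromophenyl for 3-nitrophenyl gives a 5.2-fold higher number from compound 2 to compound 3 (0.71 log units; beyond the scatter), also modest. Among the compounds with values here, no compound with two chlorine atoms has been measured, so the halogen evidence rests on the bromo step alone.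

Losing the nitro group is therefore expected to bring a modest step towards a lower number in this assay. The expected step is a 3.2-fold lower number from compound 3 to compound 4 (0.51 log units; beyond the scatter). For compound 4 the estimate is 1600 nM, with an expected range of 500 nM to 5000 nM.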

Compound 4, half-maximal inhibitory concentration: "not active" (no number reported)
For compound 4 the study gives words and no number, so the estimate cannot be set against anything.
By their numbers in this assay, from the lowest: compounds 1 and 2 (each within the scatter of the next); then compound 3.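

Going by these compounds alone, compound 4 is reported in this assay only as "not active", without a number, so no step to compound 1, compound 2 or compound 3 can be read. Nothing shown accounts for this result. The compounds shown leave open how far compound 4 lies from compound 3 on this read-out.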